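Swapping a para hydroxy for tert-butyl on the cinnamamide

A few compounds are considered here, and "the series" means these few. Any claim that something is new, unique, unknown or untested is made for them only; others in the source may bear on it.

Measured compounds:
compound 1 `CCCc1cc(N2CCCCC2)c2cc(NC(=O)/C=C/c3ccc(C(F)(F)F)cc3)ccc2n1` — > 4000 nM
compound 2 `CCCc1cc(N)c2cc(NC(=O)/C=C/c3ccc(O)cc3)ccc2n1` — 1100 nM

Of the compounds shown here, two have been tested in an assay on isolated protein for displacement of a labelled ligand from melanin-concentrating hormone receptor 1 (Homo sapiens); on this read-out higher numbers stand for weaker inhibition and lower numbers for stronger inhibition. Compound 1 `CCCc1cc(N2CCCCC2)c2cc(NC(=O)/C=C/c3ccc(C(F)(F)F)cc3)ccc2n1` gives only a limit in this assay, > 4000 nM, and no number. Compound 2 `CCCc1cc(N)c2cc(NC(=O)/C=C/c3ccc(O)cc3)ccc2n1` gives 1100 nM, the only number shown. For the measured compounds named here, of the two values, the one for compound 1 is a limit (the limit of > 4000 nM in this assay, at which 1 of the 2 values shown sits). Going by the values given here, compound 1 and compound 2 differ in more than one place, so no single step between them is counted.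

Compound 3 `CCCc1cc(N)c2cc(NC(=O)/C=C/c3ccc(C(C)(C)C)cc3)ccc2n1` has not yet been measured in this assay. It differs from compound 2 by tert-butyl in place of hydroxy on an aromatic carbon, on an aromatic carbon of a six-membered aromatic ring of carbon only, para to a large group.

Among the compounds with values here, no measured step isolates this change. The step from compound 2 to compound 3 is expected to be a 2.7-fold higher number from compound 2 to compound 3 (0.44 log units; beyond the scatter), toward weaker inhibition in this assay, beyond the usual scatter but with wide uncertainty. Compound 3 is therefore estimated at 3000 nM, with a range from 800 nM to 12000 nM, and a fair chance that only a limit is reported.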

Compound 3, half-maximal inhibitory concentration: 22 nM
Compound 3: middle estimate off by 140-fold (2.13 log units), on the high side, outside the stated range (below it).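

In this assay, exchanging hydroxy for tert-butyl on an aromatic carbon, para to a large group, gives a 50-fold lower number from compound 2 to compound 3 (1.70 log units; beyond the scatter), so this single place on the cinnamamide ring has a large influence on inhibition of the receptor while the rest of the molecule stays the same. The earlier compounds shown here could not show this, and the step also shows that hydroxy is not needed here for strong inhibition, since tert-butyl brings 4 heavy atoms and 0 hydrogen-bond donors or acceptors to this place. Compound 1 gives only a limit, > 4000 nM, and it differs from compound 3 in more than one place, so it cannot show what its trifluoromethyl contributes at this place.

With a single step, the compounds shown leave open whether the gain comes from losing hydroxy or from gaining tert-butyl, and how a methoxy group, a chlorine atom, an amine or a carboxylic acid would fare at this place on the same core. Nothing measured among these compounds accounts for the size of this step.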